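A few compounds are considered here, and "the series" means these few. Any claim that something is new, unique, unknown or untested is made for them only; others in the source may bear on it.

Compound 3 `COc1cc(Cl)cc(-c2nn(-c3cccc(NC(=O)Nc4ccc(Cl)c(C(F)(F)F)c4)c3)cc2-c2ccncc2)c1` gives 0.3% in a functional assay on NCI-H23 cells (Homo sapiens) for inhibition, read by sulforhodamine B assay, with a stated time of 48 h, tested at 10 uM; a higher number here means a weaker effect of the compound at the concentration tested, a lower number a stronger effect. Among the three compounds measured, that number is the second highest: compound 1 `COc1cc(Cl)cc(-c2nn(-c3cccc(NC(=O)c4ccc(Cl)c(Cl)c4)c3)cc2-c2ccncc2)c1` gives 75.3%, while compound 2 `O=C(Nc1cccc(-n2cc(-c3ccncc3)c(-c3cc(O)cc(Cl)c3)n2)c1)Nc1ccc(Cl)c(Cl)c1` gives -20.5%. Among the measured compounds shown here, the only single-place step measured, a number 75 percentage points lower from compound 1 to compound 3 (beyond the scatter), replaces a larger part of the molecule and so does not isolate the change considered here. Compound 4 `COc1cc(Cl)cc(-c2nn(-c3cccc(NC(=O)Nc4ccc(Cl)c(Cl)c4)c3)cc2-c2ccncc2)c1` differs from compound 3 by chloro in place of trifluoromethyl on an aromatic carbon. For the measured compounds named here, compound 2 already carries the entering group but differs from compound 4 in another place, so no measured step matches this exchange directly. In this assay the step expected is a number 5.3 percentage points lower from compound 3 to compound 4 (within the scatter), which stays within the usual scatter. Compound 4 is estimated at -5%, with a range from -30% to 20%.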

Compound 4, a percentage reported as activity, at one concentration (the size of the read-out at that concentration, not a potency): 5.72%
Estimate against measurement, compound 4: 10.7 percentage points below; low and high end bracket the measured number.
By their numbers in this assay, from the lowest: compound 2; then compounds 3 and 4 (each within the scatter of the next); then compound 1.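

In this assay, chloro in place of trifluoromethyl on this aromatic carbon, ortho to a chloro group, gives no step beyond the scatter (a number 5.4 percentage points higher from compound 3 to compound 4 (within the scatter)), so these two groups cannot be told apart here. Two changes elsewhere do register: (3,4-dichlorophenyl)amino in place of 3,4-dichlorophenyl on the carbonyl carbon (a number 69.6 percentage points lower from compound 1 to compound 4 (beyond the scatter)), and methyl in place of hydrogen on the oxygen (a number 26.2 percentage points higher from compound 2 to compound 4 (beyond the scatter)). No measurement given here explains any of these steps.

Still open, going by these compounds, is how a nitrile, an amine or a longer chain would read at this position, and whether the match between chloro and trifluoromethyl holds when the oxygen carries hydrogen instead of methyl.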